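Fluoro on the anilide ring: cytotoxicity notes

The compounds below may be only part of what the source reports. "The series", "measured", "known", "first", "only" and "open" are said of these compounds alone.

compound 1 `CCCCc1nc(Cl)c(C2NC(=O)NC(C)=C2C(=O)Nc2ccccc2)[nH]1` — "not determined" (no result reported)
compound 2 `CCCCc1nc(Cl)c(C2NC(=O)NC(C)=C2C(=O)Nc2ccccc2C)[nH]1` — "not determined" (no result reported)
compound 3 `CCCCc1nc(Cl)c(C2NC(=O)NC(C)=C2C(=O)Nc2ccccc2F)[nH]1` — > 10 ug/mL

In an ADME assay on Vero cells (Chlorocebus sabaeus) for cytotoxicity, read by MTT assay, with a stated time of 72 h (on this read-out higher numbers stand for weaker inhibition and lower numbers for stronger inhibition), compound 1 gives "not determined" (no result reported), so there is no number for it to stand on. Compound 2 likewise gives "not determined" (no result reported) in this assay. Compound 3 reaches only a limit of this assay, > 10 ug/mL, not a number. Compound 4 `CCCCc1nc(Cl)c(C2NC(=O)NC(C)=C2C(=O)Nc2ccc(F)cc2)[nH]1` differs from compound 1 by fluoro in place of hydrogen on an aromatic carbon. No measured step runs between any two of these compounds, so nothing beyond the scatter can be read from them in this assay; with compound 3 sitting at the limit of > 10 ug/mL in this assay, at which 1 of the 3 values shown sits, the expectation is that compound 4 also lands at or past that limit rather than showing a step in either direction. Compound 4 is accordingly estimated at 15 ug/mL, between 7 ug/mL and 40 ug/mL.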

Compound 4, half-maximal inhibitory concentration: > 10 ug/mL
Compound 4 ended at the assay's limit (the forecaster's own chance of this, stated with the estimate: 70%); the middle value is on the limit's open side.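

No step can be read between compound 3 and compound 4 in this assay, because each gives only a limit of the assay, not a number: the limit of > 10 ug/mL in this assay, at which 2 of the 4 values shown sit.

Going by these compounds, whether 4-fluorophenyl and 2-fluorophenyl differ in this read-out stays open.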